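Methyl to cyano on selenium: outlook for compound 4

A few compounds are considered here, and "the series" means these few. Any claim that something is new, unique, unknown or untested is made for them only; others in the source may bear on it.

Compound 3 `C[Se]c1ccc(N(C)c2nc(C3CC3)nc3ccccc23)cc1` gives the lowest number of the three measured in a functional assay on HepG2 cells (Homo sapiens) for inhibition, read by MTT assay, with a stated time of 48 h (a lower number here means a stronger inhibitor, a higher number a weaker inhibitor), 32 nM. Compound 1 `COc1ccc(N(C)c2nc(C)nc3ccccc23)cc1C(=O)OCCC[Se]C#N` gives 340 nM in this assay, and compound 2 `COc1ccc(N(C)c2nc(C)nc3ccccc23)cc1C(=O)OCCCCC[Se]C#N` gives 667 nM; both gaps to compound 3 lie beyond the scatter, so compound 3 is the most potent measured. Among the measured compounds shown here, the only single-place step, a 2.0-fold higher number from compound 1 to compound 2 (0.29 log units; within the scatter), concerns the length of a saturated chain and not the group on selenium. Compound 4 `CN(c1ccc([Se]C#N)cc1)c1nc(C2CC2)nc2ccccc12` differs from compound 3 by cyano in place of methyl on a selenium. For the measured compounds named here, no measured step bears on this exchange; compounds 1 and 2 carry cyano on selenium but differ from compound 3 in several further places, so their values cannot be read as a step. A modest weakening is expected, a 1.9-fold higher number from compound 3 to compound 4 (0.27 log units; within the scatter). Compound 4 is estimated at 60 nM, with a range from 20 nM to 200 nM.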

Compound 4, half-maximal inhibitory concentration: 41 nM
Estimate against measurement, compound 4: 1.5-fold (0.17 log units) above; measured number inside the range.
By their numbers in this assay, from the lowest: compounds 3 and 4 (each within the scatter of the next); then compounds 1 and 2 (each within the scatter of the next).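

On a selenium whose other neighbour is an aromatic carbon, cyano in place of methyl gives a 1.3-fold higher number from compound 3 to compound 4 (0.11 log units; within the scatter) in this assay, the only direct reading of this exchange among the compounds shown. In this one pair, the exchange leaves the number within the scatter, so the group on selenium can be either methyl or cyano at this place. No data shown explain this result.

Going by these compounds, whether a longer chain or a phenyl group on this selenium would read the same stays open. Also open, on these data alone, is whether an amine or a carboxylic acid on the shared core would change the reading.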